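Chloro addition to the sulfonyl aryl of compound 2

The source may hold more compounds than are shown below. What is called first, only, known or untested is meant among the compounds shown, and "the series" means these compounds.

- compound 1 `CC(NC(=O)NS(=O)(=O)c1ccc(Cl)cc1)c1cc(Br)ccc1OCc1ccccc1`: 57500 nM
- compound 2 `CCOc1ccc(Cl)cc1C(C)NC(=O)N(C)S(=O)(=O)c1ccccc1`: 10500 nM

In a functional assay on thoracic aorta (Rattus norvegicus, strain Wistar), with a stated time of 15 min (a higher number here means that more compound is needed for the effect, a lower number that less compound is needed), compound 2 has the lower of the two numbers, 10500 nM, and the gap to compound 1 lies beyond the scatter. Compound 3 `CCOc1ccc(Cl)cc1C(C)NC(=O)N(C)S(=O)(=O)c1ccc(Cl)cc1` has chloro in place of hydrogen on an aromatic carbon, para to a large group: chloro in place of hydrogen on an aromatic carbon. For the measured compounds named here, no measured pair isolates this change. Compound 1, at 57500 nM, carries the 4-chlorophenyl group but differs elsewhere too. The expected result is a small shift towards a lower number, within the scatter: a 1.2-fold lower number from compound 2 to compound 3 (0.07 log units; within the scatter). For compound 3 the estimate is 9000 nM, with an expected range of 3000 nM to 30000 nM.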

Compound 3, half-maximal effective concentration: 14600 nM
Compound 3: the middle estimate sits 1.6-fold (0.21 log units) below what was measured, and the stated range covers the measured number.
By their numbers in this assay, from the lowest: compounds 2 and 3 (each within the scatter of the next); then compound 1.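

In this assay, for the compounds shown here, phenyl to 4-chlorophenyl gives a 1.4-fold higher number from compound 2 to compound 3 (0.14 log units; within the scatter), the first reading of this change on its own. On the core of compound 2, this position therefore takes chloro in place of hydrogen with no shift beyond the scatter. No measurement shown gives a reason for this result.

From the compounds shown here alone, whether an amine, a carboxylic acid or a methoxy group at this position would move the number beyond the scatter stays open. So does whether phenyl to 4-chlorophenyl reads the same on the core of compound 1.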